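Dithiolane to dithiol swap on two anilide cores

The compounds below may be only part of what the source reports. "The series", "measured", "known", "first", "only" and "open" are said of these compounds alone.

Measured so far in a functional assay on NCI-H460 cells (Homo sapiens) for inhibition, read by MTT assay, with a stated time of 24 h, tested at 10 ug/mL; on this read-out lower numbers stand for less inhibition of growth and higher numbers for more inhibition of growth at the one concentration tested:
compound 1 `O=C(CCCCC1CCSS1)Nc1ccc(OC(F)(F)F)cc1`: 20.3%
compound 2 `O=C(CCCCC1CCSS1)Nc1cccc2ccccc12`: "not active" (no number reported)
compound 3 `O=C(CCCCC(S)CCS)Nc1ccc(OC(F)(F)F)cc1`: 29.2%

Two amides share the chain and differ in the aryl part. Compound 1 and compound 3 carry the same aromatic group; compound 2 carries a different one, and the difference between the two cores is not broken down here. Compound 4 `O=C(CCCCC(S)CCS)Nc1cccc2ccccc12` is not yet measured.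

For the measured compounds named here, the one step that has been measured is the opening of the ring on the chain, (a group of 5 heavy atoms (3 carbon, 2 sulfur; no ring) in place of a group of 5 heavy atoms (3 carbon, 2 sulfur; one five-membered non-aromatic ring with 2 hetero atoms), on a saturated chain carbon, four bonds along the chain from a carbonyl carbon). In this assay it gave a number 8.9 percentage points higher from compound 1 to compound 3 (within the scatter). So on the core of compound 1 the change leaves the read-out essentially where it was.

The same kind of change is now applied to the other core: a group of 5 heavy atoms (3 carbon, 2 sulfur; no ring) in place of a group of 5 heavy atoms (3 carbon, 2 sulfur; one five-membered non-aromatic ring with 2 hetero atoms), on a saturated chain carbon, four bonds along the chain from a carbonyl carbon. Going by the values given here, compound 2 gave no number in this assay, only the report of no activity, so nothing can be said about an order between compound 2 and compound 4, and no step is computed for this pair. The expectation for compound 4 rests on two things: the step in this assay from compound 1 to compound 3 stayed within the scatter, and compound 2 was reported as not active in this assay, "not active" (no number reported). Compound 4 is therefore expected to show little growth inhibition, with an estimated value of 8% and a range from 0% to 25%, and it is quite possible that it too is reported only as not active rather than with a number.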

Compound 4, percent growth inhibition at one concentration: "not active" (no number reported)
Compound 4: no number reported, and the estimate cannot be compared.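

In this assay compound 2 gives "not active" (no number reported) and compound 4 gives "not active" (no number reported) and so no step can be read for this pair. The compounds shown leave open whether 1,3-disulfanylpropyl in place of the ring changes growth inhibition on the core of compound 2 at all. No measured evidence bears on this result.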